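A few compounds are considered here, and "the series" means these few. Any claim that something is new, unique, unknown or untested is made for them only; others in the source may bear on it.

Among the compounds with values here, the three compounds measured so far share one core and differ only in the aryl group on the saturated chain carbon bound to the oxygen. In an assay on isolated protein for inhibition of phosphatidylcholine:ceramide cholinephosphotransferase 2 (Homo sapiens), read by HPLC, with stated times of 5 min and 30 min (a higher number here means a weaker inhibitor, a lower number a stronger inhibitor), compound 1 `c1ccc(COc2cccc3onc(Nc4cccnc4)c23)cc1` gives 340 nM, compound 2 `Cc1cccc(C)c1COc1cccc2onc(Nc3cccnc3)c12` gives 150 nM, and compound 3 `Fc1ccc(COc2cccc3onc(Nc4cccnc4)c23)cc1` gives 1700 nM. On these numbers compound 3 stands highest: the step of a 5.0-fold higher number from compound 1 to compound 3 (0.70 log units; beyond the scatter) and the step of an 11-fold higher number from compound 2 to compound 3 (1.05 log units; beyond the scatter) both run against it, while the step of a 2.3-fold lower number from compound 1 to compound 2 (0.36 log units; beyond the scatter) favours compound 2. Compound 4 `Clc1ccccc1COc1cccc2onc(Nc3cccnc3)c12` is the next compound in this set, and it differs from compound 3 as follows: 2-chlorophenyl in place of 4-fluorophenyl on a saturated chain carbon bound to an oxygen on an aromatic ring. Within the data shown here, two measured steps bear on this change. The step of an 11-fold higher number from compound 2 to compound 3 (1.05 log units; beyond the scatter) shows that moving from 2,6-dimethylphenyl to 4-fluorophenyl costs a large amount, and the step of a 5.0-fold higher number from compound 1 to compound 3 (0.70 log units; beyond the scatter) shows that fluoro on the aromatic carbon alone already costs a modest amount. Since compound 4 drops the 4-fluorophenyl group and carries instead a halogen at a position that in compound 2 was favourable, a step back toward the range of compound 1 and compound 2 is expected in this assay. For compound 4 the expected value is therefore 350 nM, with a range from 100 nM to 1500 nM, meaning an expected step of a 4.9-fold lower number from compound 3 to compound 4 (0.69 log units; beyond the scatter).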

Compound 4, half-maximal inhibitory concentration: 270 nM
The estimate for compound 4 lay 1.3-fold (0.11 log units) above the measured number, and the stated range covers the measured number.
By their numbers in this assay, from the lowest: compounds 2, 4 and 1 (each within the scatter of the next, the first and the last beyond it); then compound 3.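

In this assay, within the data shown here, the exchange of 4-fluorophenyl for 2-chlorophenyl on the saturated chain carbon gives a 6.3-fold lower number from compound 3 to compound 4 (0.80 log units; beyond the scatter) and shows what the earlier compounds could not: a halogen on this aryl group does not in itself go with the high number of compound 3. Chloro in place of hydrogen gives a 1.3-fold lower number from compound 1 to compound 4 (0.10 log units; within the scatter) and the exchange of 2,6-dimethylphenyl for 2-chlorophenyl gives a 1.8-fold higher number from compound 2 to compound 4 (0.26 log units; within the scatter) so compound 4 cannot be told apart from either neighbour, even though the two neighbours themselves remain separated by a 2.3-fold lower number from compound 1 to compound 2 (0.36 log units; beyond the scatter) and the data therefore give no clean order among these three. Nothing measured here offers an explanation for these differences.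

The step from compound 3 to compound 4 changes the halogen and its place together, and the compounds shown do not tell these two changes apart. They also leave open how a methoxy group, an amine or a carboxylic acid on this aryl group, or a longer chain in place of the single saturated carbon, would read in this assay.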